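This account rests on a few compounds, and the source may have more. Where it says the series, first, only, none or still open, it means among the compounds named here.

Compound 1 `CCNC(=O)c1noc(-c2cc(C(C)C)c(O)cc2O)c1-c1cc(CNC)no1` gives 164 nM in a functional assay on HCT-116 cells (Homo sapiens) for inhibition (on this read-out lower numbers stand for stronger inhibition and higher numbers for weaker inhibition), the highest of the three numbers recorded there. Compound 2 `CCCNCc1cc(-c2c(C(=O)NCC)noc2-c2cc(C(C)C)c(O)cc2O)on1` gives 117 nM, and the step of a 1.4-fold lower number from compound 1 to compound 2 (0.15 log units; within the scatter) stays within the scatter. Compound 3 `CCNC(=O)c1noc(-c2cc(C(C)C)c(O)cc2O)c1-c1cnn(C)c1` gives 41 nM, reached from compound 1 by the step of a 4.0-fold lower number from compound 1 to compound 3 (0.60 log units; beyond the scatter) and from compound 2 by the step of a 2.9-fold lower number from compound 2 to compound 3 (0.46 log units; beyond the scatter).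

Compound 4 `CCNC(=O)c1noc(-c2cc(C(C)C)c(O)cc2O)c1-c1cnn(CC)c1` has not yet been measured. It differs from compound 1 as follows: 1-ethyl-1H-pyrazol-4-yl in place of 3-((methylamino)methyl)-1,2-oxazol-5-yl on an aromatic carbon. For the measured compounds named here, the change is the same kind of swap as the one from compound 1 to compound 3, differing only in that an ethyl rather than a methyl sits on the pyrazole nitrogen. The step of a 4.0-fold lower number from compound 1 to compound 3 (0.60 log units; beyond the scatter) therefore bears most directly on it, and the step of a 2.9-fold lower number from compound 2 to compound 3 (0.46 log units; beyond the scatter) points the same way. Compound 4 is thus expected to land close to compound 3, meaning a step of about a 3.6-fold lower number from compound 1 to compound 4 (0.56 log units; beyond the scatter) beyond the scatter. The estimate for compound 4 in this assay is 45 nM, with a range from 20 nM to 100 nM.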

Compound 4, half-maximal inhibitory concentration: 26 nM
The estimate for compound 4 lay 1.7-fold (0.24 log units) above the measured number; low and high end bracket the measured number.
By their numbers in this assay, from the lowest: compounds 4 and 3 (each within the scatter of the next); then compounds 2 and 1 (each within the scatter of the next).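

In this assay, 1-ethyl-1H-pyrazol-4-yl in place of the aminomethyl-bearing oxazolyl groups again gives steps beyond the scatter (a 6.3-fold lower number from compound 1 to compound 4 (0.80 log units; beyond the scatter)) and (a 4.5-fold lower number from compound 2 to compound 4 (0.65 log units; beyond the scatter)), so the gain seen with 1-methyl-1H-pyrazol-4-yl on this aromatic carbon is not confined to that one group. The further change, methyl in place of hydrogen on the saturated chain carbon bound to an aromatic nitrogen, stays within the scatter (a 1.6-fold lower number from compound 3 to compound 4 (0.20 log units; within the scatter)), so compound 3 and compound 4 cannot be told apart on this read-out. Nothing available explains these differences.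

The compounds shown leave open how a propyl chain or a 2-hydroxyethyl group would read in place of that ethyl. They also leave open how a phenyl or pyridinyl group would read on the same aromatic carbon.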